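The source may report more compounds than this note shows. Statements on the series, on what has been measured and on what is new or still open speak of the compounds shown alone.

Values in a functional assay on HL-60 cells (Homo sapiens) for cytotoxicity, read by WST assay, with a stated time of 48 h (on this read-out lower numbers stand for an effect already at smaller amounts and higher numbers for an effect only at larger amounts of compound), so far:
compound 1 `O=C1OC[C@H](Cc2ccccc2)[C@H]1Cc1ccccc1O` gives 83000 nM
compound 2 `O=C1OC[C@H](Cc2ccccc2)[C@H]1Cc1cccc(F)c1` gives 75000 nM
compound 3 `COCOc1ccc(C[C@H]2C(=O)OC[C@@H]2Cc2ccccc2)cc1` gives 71000 nM

Compound 3 stands level with the other two compounds, as all three values lie within the scatter of one another. The next comparison is compound 4 `Cc1ccc(C[C@H]2C(=O)OC[C@@H]2Cc2ccccc2)cc1` with the change methyl in place of methoxymethoxy on an aromatic carbon on the same ring position. This is methyl in place of methoxymethoxy on an aromatic carbon, para to a large group. Within the data shown here, the one measured step, a 1.1-fold lower number from compound 1 to compound 2 (0.04 log units; within the scatter), involves other groups and bears on this only indirectly. It stays within the scatter, so no step beyond the scatter is expected in this assay here. The estimated 1.0-fold lower number from compound 3 to compound 4 (0.01 log units; within the scatter) stays within the scatter too. Compound 4 is expected at 70000 nM within an estimated range of 40000 nM to 120000 nM in this series.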

Compound 4, half-maximal effective concentration: 44000 nM
Estimate against measurement, compound 4: 1.6-fold (0.20 log units) above, and the stated range covers the measured number.
By their numbers in this assay, from the lowest: compounds 4, 3, 2 and 1 (each within the scatter of the next).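

In this assay the position para to a large group tolerates a drop from methoxymethoxy, with 4 heavy atoms and 2 hydrogen-bond acceptors, to methyl, with 1 heavy atom and 0 acceptors, giving a 1.6-fold lower number from compound 3 to compound 4 (0.21 log units; within the scatter). Across the other two aryl changes, the series shows a 1.7-fold lower number from compound 2 to compound 4 (0.23 log units; within the scatter) and a 1.9-fold lower number from compound 1 to compound 4 (0.28 log units; within the scatter), so 4-methylphenyl stands level with 3-fluorophenyl and 2-hydroxyphenyl. No available data explain these small differences.

Still open, on these data alone, is whether an amine or a carboxylic acid on this aromatic carbon would give a step beyond the scatter.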